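This account rests on a few compounds, and the source may have more. Where it says the series, first, only, none or still open, it means among the compounds named here.

Measured so far in a functional assay on BXPC-3 cells (Homo sapiens) for antiproliferative activity, read by MTT assay, with a stated time of 24 h; a higher number here means a weaker inhibitor, a lower number a stronger inhibitor:
- compound 1 `CCn1c(C(=O)NCC(=O)OC)ccc1C(CC)(CC)c1ccc(OCS(=O)(=O)c2ccccc2)c(C)c1`: 20000 nM
- compound 2 `CCn1c(C(=O)NCCC(=O)OC)ccc1C(CC)(CC)c1ccc(OCS(=O)(=O)c2ccccc2)c(C)c1`: > 50000 nM
- compound 3 `CCn1c(C(=O)NCCN)ccc1C(CC)(CC)c1ccc(OCS(=O)(=O)c2ccccc2)c(C)c1`: 6430 nM

The entry for compound 2, > 50000 nM, is a limit of the assay and not a number. Among the measured compounds shown here, compound 3, at 6430 nM, has the lowest of the numbers so far, and it is the starting point for the next change.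

Compound 4 `CCN(CC)CCNC(=O)c1ccc(C(CC)(CC)c2ccc(OCS(=O)(=O)c3ccccc3)c(C)c2)n1CC` carries diethylamino in place of amino on a saturated chain carbon, two bonds along the chain from an amide-type nitrogen.

For the measured compounds named here, two measured steps bear on this position: a 3.1-fold lower number from compound 1 to compound 3 (0.49 log units; beyond the scatter) and an at least 7.7-fold lower number from compound 2 to compound 3 (0.89 log units; beyond the scatter). Both replace an ester-bearing chain end, and neither alters the amino group itself, so they give no direction for this change. Going by the values given here, they show only that changes at this chain end can move the number in this assay. A step smaller than these is expected, and one in either direction remains possible. The expected result is a 1.3-fold lower number from compound 3 to compound 4 (0.11 log units; within the scatter).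

For compound 4 the estimate is 5000 nM, with an expected range from 1500 nM to 18000 nM.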

Compound 4, half-maximal inhibitory concentration: 6270 nM
Compound 4: middle estimate off by 1.3-fold (0.10 log units), on the low side; measured number inside the range.
By their numbers in this assay, from the lowest: compounds 4 and 3 (each within the scatter of the next); then compound 1. At a limit, above all of these: compound 2.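

In this assay, a 1.0-fold lower number from compound 3 to compound 4 (0.01 log units; within the scatter) shows that amino and diethylamino on a saturated chain carbon, two bonds along the chain from an amide-type nitrogen, are not told apart, although the entering group has 5 heavy atoms against 1 and 0 hydrogen-bond donors against 1. The lower number seen for the primary amine against the shorter ester chain end holds for the diethylamino compound as well, with a 3.2-fold lower number from compound 1 to compound 4 (0.50 log units; beyond the scatter). Against the longer ester chain end the reading is an at least 7.9-fold lower number from compound 2 to compound 4 (0.90 log units; beyond the scatter), and the entry for compound 2 is a limit of the assay and not a number: the limit of > 50000 nM in this assay, at which 1 of the 4 values shown sits.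

Open, as far as these compounds go, is whether a piperidine or a morpholine at this chain end would stay level with compound 3 and compound 4. Also open, from the compounds shown here alone, is how a longer chain carrying the diethylamino group, or a carboxylic acid in place of the ester, would read.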